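Amide Nitrogen Changes on a Shared Core

The source may hold more compounds than are shown below. What is called first, only, known or untested is meant among the compounds shown, and "the series" means these compounds.

Compound 1 `C=CC1=C(C(=O)NCc2ccc(C)cc2)C(c2ccc(OC)cc2)OC1`, in a functional assay on A549 cells (Homo sapiens) for cytotoxicity, read by MTT assay, with a stated time of 24 h (on this read-out higher numbers stand for weaker inhibition and lower numbers for stronger inhibition), gives > 100000 nM, which is a limit of the assay and not a number.
Compound 2 `C=CC1=C(C(=O)Nc2ccc(C)cc2)C(c2ccc(OC)cc2)OC1` gives > 100000 nM, again a limit.
Compound 3 `C=CC1=C(C(=O)Nc2ccccc2)C(c2ccc(OC)cc2)OC1` gives > 100000 nM, also a limit.

Compound 3 therefore stands at the limit of > 100000 nM in this assay, at which 3 of the 3 values shown sit, and no measured value sets it apart from the others. Among the measured compounds shown here, the three measured steps, a step that the two limits leave unreadable from compound 1 to compound 2, a step that the two limits leave unreadable from compound 1 to compound 3 and a step that the two limits leave unreadable from compound 2 to compound 3, all run between limits, so their sizes cannot be read; they tell only that changing the group on the amide-type nitrogen, or removing a methyl from an aromatic carbon, did not bring any compound below the limit.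

Compound 4 `C=CC1=C(C(=O)NCCC)C(c2ccc(OC)cc2)OC1` carries a further change at the same place: propyl in place of phenyl on an amide-type nitrogen. For the measured compounds named here, none of the measured steps gives a readable size to build on, so no step beyond the scatter is expected; the expected step that the limit leaves unreadable from compound 3 to compound 4 is no more than a guess that compound 4 stays where its neighbours sit. Compound 4 is thus estimated at 150000 nM, with a range from 40000 nM to 600000 nM, most likely reported again as a limit.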

Compound 4, half-maximal inhibitory concentration: > 100000 nM
Compound 4: no number, only a limit; the forecaster's own chance of this, stated with the estimate: 85%; the middle value is on the limit's open side.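

In this assay compound 4 also gives only a limit, so its steps to compound 1, compound 2 and compound 3 cannot be read. The compounds shown leave open how far each lies past that limit, and whether any group on the amide-type nitrogen would give a measurable value.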